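This account rests on a few compounds, and the source may have more. Where it says the series, first, only, none or still open, it means among the compounds named here.

Of the compounds shown here, three built on a shared core have been measured in a functional assay on HepG2 cells (Homo sapiens) for cytotoxicity, read by MTT assay, with a stated time of 24 h; a higher number here means a weaker inhibitor, a lower number a stronger inhibitor. Compound 1 `CN1C/C(=C\c2ccncc2)C(=O)/C(=C/c2ccccc2C(F)(F)F)C1` gives 3300 nM. Compound 2 `O=C1/C(=C/c2ccncc2)CN(S(=O)(=O)c2ccc([N+](=O)[O-])cc2)C/C1=C\c1ccccc1C(F)(F)F` gives 13400 nM. Compound 3 `O=C1/C(=C/c2ccncc2)CN(S(=O)(=O)c2ccc(F)cc2)C/C1=C\c1ccccc1C(F)(F)F` gives 4010 nM. Compound 3 thus stands second highest of the three numbers, nearest to compound 1 and furthest from compound 2. The steps among them are a 4.1-fold higher number from compound 1 to compound 2 (0.61 log units; beyond the scatter), a 1.2-fold higher number from compound 1 to compound 3 (0.08 log units; within the scatter) and a 3.3-fold lower number from compound 2 to compound 3 (0.52 log units; beyond the scatter).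

Compound 4 `N#Cc1ccc(S(=O)(=O)N2C/C(=C\c3ccncc3)C(=O)/C(=C/c3ccccc3C(F)(F)F)C2)cc1` differs from compound 3 in one place: cyano in place of fluoro on an aromatic carbon. Among the compounds with values here, the step that bears most directly on this change is the one from compound 2 to compound 3, where a different group on the same aromatic carbon, para to a large group, moved the number modestly, while the step from compound 1 to compound 3 stayed within the scatter. Within the data shown here, a cyano group here has no measured precedent, so the expected step is modest and uncertain, more likely upward than downward. For compound 4 the estimated step is a 1.6-fold higher number from compound 3 to compound 4 (0.21 log units; within the scatter). Compound 4 is therefore expected to give about 6500 nM, within a range from 2500 nM to 16000 nM.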

Compound 4, half-maximal inhibitory concentration: 5920 nM
The estimate for compound 4 lay 1.1-fold (0.04 log units) above the measured number, within the range that was stated.
By their numbers in this assay, from the lowest: compounds 1, 3 and 4 (each within the scatter of the next); then compound 2.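

In this assay, cyano in place of fluoro gives a 1.5-fold higher number from compound 3 to compound 4 (0.17 log units; within the scatter), so these two groups on this aromatic carbon cannot be told apart. Cyano in place of nitro gives a 2.3-fold lower number from compound 2 to compound 4 (0.35 log units; beyond the scatter), which leaves nitro as the only group of the three at this carbon that is separated from both others by more than the scatter. The (4-cyanophenyl)sulfonyl group in place of methyl gives a 1.8-fold higher number from compound 1 to compound 4 (0.25 log units; within the scatter), so, like the (4-fluorophenyl)sulfonyl group, it is not separated from methyl on the ring nitrogen, and no measurement shown accounts for any of these steps.

The compounds shown leave open whether an amine, a methoxy group or a carboxylic acid on this aromatic carbon would give a step beyond the scatter from compound 3. They also leave open what a plain phenylsulfonyl group, with only hydrogen at this carbon, would give.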